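The source may hold more compounds than are shown below. What is called first, only, known or untested is meant among the compounds shown, and "the series" means these compounds.

Measured so far in an assay on DDT1 cells (Cricetulus griseus) for binding affinity to adenosine receptor A1 (Homo sapiens), read by radioligand binding; a lower number here means a stronger inhibitor, a higher number a weaker inhibitor: compound 1 `CNC(=O)OC[C@H]1OC(n2cnc3c(NC4CCOC4)nc(Cl)nc32)[C@H](O)[C@@H]1O` gives 96 nM. Compound 2 `C/N=C(\S)OC[C@H]1OC(n2cnc3c(NC4CCOC4)ncnc32)[C@H](O)[C@@H]1O` gives 45 nM. Compound 3 `C/N=C(\S)OC[C@H]1OC(n2cnc3c(NC4CCOC4)nc(Cl)nc32)[C@H](O)[C@@H]1O` gives 71 nM.

Compound 2 holds the lowest number of the three; the step of a 1.6-fold higher number from compound 2 to compound 3 (0.20 log units; within the scatter) stays within the scatter, while the gap to compound 1 lies beyond it. Compound 4 `CCNC(=O)OC[C@H]1OC(n2cnc3c(NC4CCOC4)ncnc32)[C@H](O)[C@@H]1O` differs from compound 2 by a group of 5 heavy atoms (3 carbon, 1 nitrogen, 1 oxygen; no ring) in place of a group of 4 heavy atoms (2 carbon, 1 nitrogen, 1 sulfur; no ring), on an oxygen on a saturated carbon. Among the compounds with values here, the one measured step that bears on this exchange, a 1.4-fold lower number from compound 1 to compound 3 (0.13 log units; within the scatter), runs in the reverse direction and stays within the scatter; no measured pair separates ethylcarbamoyl from the methyl analogue. No step beyond the scatter is therefore expected in this assay, and compound 4 is estimated at 55 nM (range 25 nM to 120 nM), a step of a 1.2-fold higher number from compound 2 to compound 4 (0.09 log units; within the scatter).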

Compound 4, inhibition constant: 167 nM
Estimate against measurement, compound 4: 3.0-fold (0.48 log units) below; measured number above the stated range.
By their numbers in this assay, from the lowest: compounds 2, 3, 1 and 4 (each within the scatter of the next, the first and the last beyond it).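

In this assay the place on an oxygen on a saturated carbon now shows a real response: a 3.7-fold higher number from compound 2 to compound 4 (0.57 log units; beyond the scatter) with ethylcarbamoyl entering, a step beyond the scatter. Within the data shown here, the only earlier exchange there, a 1.4-fold lower number from compound 1 to compound 3 (0.13 log units; within the scatter), stayed within the scatter, so exchanges at this place do not all read alike. Nothing available accounts for the size of this step.

The compounds shown leave open whether the step follows the extra carbon or the oxygen in place of sulfur. They also leave open how a propylcarbamoyl group or a carboxylic acid at this place would read, and whether chloro on the core changes the step.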